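This account rests on a few compounds, and the source may have more. Where it says the series, first, only, none or still open, it means among the compounds named here.

Measured so far:
compound 1, `CC(C(=O)NCc1ccc(C(F)(F)F)nc1NCC1CCN(C(=O)OC(C)(C)C)CC1)c1ccc(NS(C)(=O)=O)c(F)c1`: 19.3 nM
compound 2, `CCCCN(C)c1nc(C(F)(F)F)ccc1CNC(=O)C(C)c1ccc(NS(C)(=O)=O)c(F)c1`: 0.8 nM
compound 3, `C[C@H](C(=O)NCc1ccc(C(F)(F)F)nc1N1CC[C@H](N(C)C)C1)c1ccc(NS(C)(=O)=O)c(F)c1`: 103 nM

In a functional assay on CHO-K1 cells for antagonist activity at transient receptor potential cation channel subfamily V member 1 (Homo sapiens), read by FLIPR (on this read-out higher numbers stand for weaker inhibition and lower numbers for stronger inhibition), compound 2 gives the lowest number of the three; compound 1 lies beyond the scatter above it, and compound 3 further still. Going by the values given here, no two measured compounds differ in a single place, so no step can be read off directly. Compound 4, `COC1CCN(c2nc(C(F)(F)F)ccc2CNC(=O)C(C)c2ccc(NS(C)(=O)=O)c(F)c2)CC1`, has yet to be measured. Its change from compound 2: 4-methoxypiperidin-1-yl in place of butyl(methyl)amino on an aromatic carbon. Both other measured compounds carry a different group than compound 2 at this part of the core and both give higher numbers, so a step upward beyond the scatter is expected here, a 15-fold higher number from compound 2 to compound 4 (1.18 log units; beyond the scatter), though a smaller one than to compound 3. Compound 4 is estimated at 12 nM, between 3 nM and 50 nM.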

Compound 4, inhibition constant: 2.4 nM
Estimate against measurement, compound 4: 5.0-fold (0.70 log units) above; the measured number lies below the stated range.
By their numbers in this assay, from the lowest: compound 2; then compound 4; then compound 1; then compound 3.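

In this assay, 4-methoxypiperidin-1-yl in place of butyl(methyl)amino on the aromatic carbon next to the ring nitrogen gives a 3.0-fold higher number from compound 2 to compound 4 (0.48 log units; beyond the scatter) as a modest step. This position therefore accepts a six-membered non-aromatic ring with an added oxygen, and the open-chain amine is not needed for a low number, though compound 2 stays lower. Nothing on hand accounts for the size of this step.

The compounds shown do not separate the contribution of the ring from that of the methoxy group. From the compounds shown here alone, how a plain piperidine, a morpholine or a dimethylamino group would compare also remains open.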